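The source may report more compounds than this note shows. Statements on the series, on what has been measured and on what is new or still open speak of the compounds shown alone.

In a functional assay on MKN-45 cells (Homo sapiens) for cytotoxicity, read by MTT assay, with a stated time of 72 h (a lower number here means a stronger inhibitor, a higher number a weaker inhibitor), compound 1 `COc1cc2c(Oc3ccc(NC(=O)c4nn(-c5ccccc5)c(=O)c5ccccc45)cc3F)ccnc2cc1OCCCN1CCCC1` gives 530 nM. Compound 2 `COc1cc2c(Oc3ccc(NC(=O)c4nn(-c5ccccc5F)c(=O)c5ccccc45)cc3F)ccnc2cc1OCCCN1CCCC1` gives 140 nM, and compound 3 `COc1cc2c(Oc3ccc(NC(=O)c4nn(-c5ccccc5)c(=O)c5ccccc45)cc3F)ccnc2cc1OCCCN1CCN(C)CC1` gives 620 nM, the highest of the three numbers: the gap from compound 1 to compound 3 is a 1.2-fold higher number from compound 1 to compound 3 (0.07 log units; within the scatter), while compound 2 sits well apart. Compound 4 `COc1cc2c(Oc3ccc(NC(=O)c4nn(-c5ccc(Br)cc5)c(=O)c5ccccc45)cc3F)ccnc2cc1OCCCN1CCN(C)CC1` differs from compound 3 by bromo in place of hydrogen on an aromatic carbon, on an aromatic carbon of a six-membered aromatic ring of carbon only, para to a large group. Going by the values given here, the one measured step that touches this phenyl, a 3.8-fold lower number from compound 1 to compound 2 (0.58 log units; beyond the scatter), placed a fluoro rather than a bromo on that ring and at another of its carbons, so it bears only loosely on the present change. A smaller drop is therefore expected, a 2.1-fold lower number from compound 3 to compound 4 (0.32 log units; beyond the scatter), giving compound 4 an estimated 300 nM, within 120 nM to 800 nM.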

Compound 4, half-maximal inhibitory concentration: 350 nM
Compound 4: middle estimate off by 1.2-fold (0.07 log units), on the low side, and the stated range covers the measured number.
By their numbers in this assay, from the lowest: compound 2; then compounds 4, 1 and 3 (each within the scatter of the next).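

In this assay, bromo in place of hydrogen on this aromatic carbon, para to a large group, gives a 1.8-fold lower number from compound 3 to compound 4 (0.25 log units; within the scatter), so the effect of this change cannot be told apart from the usual scatter. Going by these compounds alone, this is the first sign that this carbon of the phenyl can carry a bromine atom without a clear loss or gain in the cell result. Nothing shown explains this result. The compounds shown leave open how a nitrile or a carboxylic acid would fare at this carbon. They also leave open whether bromo would have the same effect with the pyrrolidin-1-yl chain of compound 1.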